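Chain terminus swap: hydroxymethyl to methylcarbamoyl

This account rests on a few compounds, and the source may have more. Where it says the series, first, only, none or still open, it means among the compounds named here.

Measured so far in a functional assay on LNCaP cells (Homo sapiens) for antiproliferative activity; a higher number here means a weaker inhibitor, a lower number a stronger inhibitor:
- compound 1, `COCC[C@@H]1C[C@@H](c2ccc(Cl)c(Cl)c2)[C@H](NC(=O)c2cc(-c3c(Cl)cnn3C)c(Cl)o2)CN1`: 250 nM
- compound 2, `Cn1ncc(Cl)c1-c1cc(C(=O)N[C@@H]2CN[C@H](CCO)C[C@H]2c2ccc(Cl)c(Cl)c2)oc1Cl`: 160 nM

Going by the values given here, compound 2 stands with compound 1 as its only neighbour, and the two numbers lie within the scatter of each other: the step of a 1.6-fold lower number from compound 1 to compound 2 (0.19 log units; within the scatter) carries no weight on its own. That step is the one edit on the chain attached to the saturated ring carbon, and it touched only the oxygen substituent.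

Compound 3, `CNC(=O)C[C@@H]1C[C@@H](c2ccc(Cl)c(Cl)c2)[C@H](NC(=O)c2cc(-c3c(Cl)cnn3C)c(Cl)o2)CN1`, remains to be measured. Its difference from compound 2 is methylcarbamoyl in place of hydroxymethyl on a saturated chain carbon bound to a saturated ring carbon. Among the compounds with values here, this is a larger edit than the one measured step, since the whole terminal group is exchanged rather than a methyl on it; no measured pair bears on a carbamoyl at this position. The step of a 1.6-fold lower number from compound 1 to compound 2 (0.19 log units; within the scatter) is the nearest guide and shows the chain end tolerating change without a shift beyond the scatter, so the expectation for compound 3 is a step of a 1.4-fold higher number from compound 2 to compound 3 (0.14 log units; within the scatter), with wide uncertainty. Compound 3 is therefore estimated at 220 nM, with a range from 70 nM to 700 nM.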

Compound 3, half-maximal inhibitory concentration: 40 nM
The estimate for compound 3 lay 5.5-fold (0.74 log units) above the measured number; measured number below the stated range.
By their numbers in this assay, from the lowest: compound 3; then compounds 2 and 1 (each within the scatter of the next).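

In this assay, the end of the chain on the saturated ring carbon proves to be a place where the read-out moves. Methylcarbamoyl in place of hydroxymethyl gives a 4.0-fold lower number from compound 2 to compound 3 (0.60 log units; beyond the scatter), and methylcarbamoyl in place of methoxymethyl gives a 6.3-fold lower number from compound 1 to compound 3 (0.80 log units; beyond the scatter), whereas the edit on the oxygen substituent alone gave only a 1.6-fold lower number from compound 1 to compound 2 (0.19 log units; within the scatter). So among these three compounds, exchanging the whole terminal group matters more than capping its oxygen, although no measurement on hand speaks to what lies behind the gain.

Going by these compounds alone, the single exchange alters the carbonyl, the nitrogen and the nitrogen's methyl together, so these compounds do not show which of them carries the step. On these data alone, it remains open whether an unsubstituted carbamoyl, a dimethylcarbamoyl, a carboxylic acid or a methylcarbamoyl on a longer chain would hold the lower number at this place.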